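The compounds below may be only part of what the source reports. "The series", "measured", "known", "first", "only" and "open" are said of these compounds alone.

Measured so far in a functional assay on A549 cells (Homo sapiens) for antiproliferative activity, read by CCK-8 assay, with a stated time of 72 h; on this read-out lower numbers stand for stronger inhibition and higher numbers for weaker inhibition:
- compound 1, `O=C(Nc1cccc(-c2oc3cc(-c4ccc(F)cc4)ccc3c(=O)c2O)c1)c1ccc(F)cc1`: 6930 nM
- compound 2, `COc1ccccc1C(=O)Nc1cccc(-c2oc3cc(-c4ccc(F)cc4)ccc3c(=O)c2O)c1`: 11700 nM
- compound 3, `CCc1ccc(C(=O)Nc2cccc(-c3oc4cc(-c5ccc(F)cc5)ccc4c(=O)c3O)c2)cc1`: 18500 nM

Compound 3 carries the highest of the three numbers in this assay. The nearer step is a 1.6-fold higher number from compound 2 to compound 3 (0.20 log units; within the scatter), so compound 2 and compound 3 are not separated. The further step is a 2.7-fold higher number from compound 1 to compound 3 (0.43 log units; beyond the scatter), a modest but real step upward in number, that is, toward weaker inhibition, when ethyl replaces fluoro on the aromatic carbon of the amide aryl group. The step from compound 1 to compound 2 is a 1.7-fold higher number from compound 1 to compound 2 (0.23 log units; within the scatter), again not separated.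

Compound 4, `CCCc1ccc(C(=O)Nc2cccc(-c3oc4cc(-c5ccc(F)cc5)ccc4c(=O)c3O)c2)cc1`, is the next member, not yet measured. It differs from compound 3 by methyl in place of hydrogen on a saturated chain carbon, two bonds along the chain from an aromatic carbon. Going by the values given here, no measured pair repeats a chain-lengthening of this kind; the only step touching this part of the molecule, from fluoro to ethyl, is a 2.7-fold higher number from compound 1 to compound 3 (0.43 log units; beyond the scatter), and the exchanges among the three aryl amides otherwise stay within the scatter. The expected step in this assay is therefore small, a 1.2-fold higher number from compound 3 to compound 4 (0.08 log units; within the scatter), leaning if anything toward a higher number. The estimate for compound 4 in this assay is 22000 nM, with a range from 9000 nM to 55000 nM.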

Compound 4, half-maximal inhibitory concentration: 47600 nM
For compound 4 the middle estimate is 2.2-fold (0.34 log units) below the measured one; the range from low to high includes it.
By their numbers in this assay, from the lowest: compounds 1, 2 and 3 (each within the scatter of the next, the first and the last beyond it); then compound 4.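

In this assay, going from ethyl to propyl on the amide aryl group gives a 2.6-fold higher number from compound 3 to compound 4 (0.41 log units; beyond the scatter) and is the only pure chain extension in the series, so this position responds to a change as small as methyl in place of hydrogen on the saturated chain. The change also separates compound 4 from the other two aryl amides, with a 4.1-fold higher number from compound 2 to compound 4 (0.61 log units; beyond the scatter) and a 6.9-fold higher number from compound 1 to compound 4 (0.84 log units; beyond the scatter) as its steps, and fluoro, ethyl and propyl at this place now form a rising run through compound 1, compound 3 and compound 4, while compound 2, with its 2-methoxyphenyl group, stands outside that run and within the scatter of both compound 1 and compound 3. Nothing measured bears on why the number rises as the chain grows.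

Three points along one chain do not show whether butyl or a longer chain would continue the rise, or whether a branched group such as isopropyl would follow the same course. Also open, going by these compounds, is whether an amine or a carboxylic acid at the end of the propyl chain would keep or reverse the direction seen here.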